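Removing one chloro from a dichloro amide

This account rests on a few compounds, and the source may have more. Where it says the series, first, only, none or still open, it means among the compounds named here.

Three amides that share one core have been measured. Compound 1 `COc1ccc(C(=O)Nc2ccc3c(C)cc(=O)[nH]c3c2)cc1OC` gives 1.46 in a physicochemical assay for lipophilicity; a higher number here means a more lipophilic compound, a lower number a more polar compound. Compound 2 `Cc1cc(=O)[nH]c2cc(NC(=O)c3ccc(Cl)cc3Cl)ccc12` gives 1.83 in this assay, and compound 3 `Cc1cc(=O)[nH]c2cc(NC(=O)c3cccc4ccccc34)ccc12` gives 1.72. Among these three numbers compound 2 stands highest; the value of compound 3 lies within the scatter of it, so the two cannot be told apart, while the value of compound 1 lies beyond the scatter below it.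

Compound 4 `Cc1cc(=O)[nH]c2cc(NC(=O)c3ccc(Cl)cc3)ccc12` has not yet been measured in this assay. It differs from compound 2 in one place: hydrogen in place of chloro on an aromatic carbon. With one chlorine fewer and nothing new added, the expectation is a modest drop, roughly at the edge of the scatter; compound 1, which also carries no chlorine, sits lower than compound 2, but its substituents differ in other ways too, so it does not fix the size of the step. The expected step from compound 2 to compound 4 is a number 0.33 log units lower from compound 2 to compound 4 (beyond the scatter). Compound 4 is therefore estimated at 1.5, with a range from 1.2 to 1.8.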

Compound 4, partition coefficient: 1.69
Compound 4: middle estimate off by 0.19 log units, on the low side, and the stated range covers the measured number.
By their numbers in this assay, from the lowest: compounds 1, 4, 3 and 2 (each within the scatter of the next, the first and the last beyond it).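

In this assay, the number gives a number 0.14 log units lower from compound 2 to compound 4 (within the scatter) when hydrogen takes the place of the chloro on the aromatic carbon ortho to a large group. Among these compounds, this is the first pair here that differs in only one place, so it gives the first direct reading of a single change: with one chlorine fewer, compound 4 cannot be told apart from compound 2 in this measurement. No measurement shown offers an explanation for the size of this step.

On these data alone, whether an amine or a carboxylic acid on this same carbon would give a step beyond the scatter remains open. So does the outcome of replacing the remaining chloro group, since no step at that place is available.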